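Cyano in Place of Fluoro: Expecting Another Limit

A few compounds are considered here, and "the series" means these few. Any claim that something is new, unique, unknown or untested is made for them only; others in the source may bear on it.

The two measured compounds share one core, seen in compound 1 `C/C(=C\c1cc(-c2ccc(C)cc2)cs1)C(N)=O` and compound 2 `C/C(=C\c1cc(-c2ccc(F)cc2)cs1)C(N)=O`. In a functional assay on BGC-823 cells (Homo sapiens) for cytotoxicity, read by CCK-8 assay, with a stated time of 24 h (a lower number here means a stronger inhibitor, a higher number a weaker inhibitor), compound 1 gives only a limit of the assay, > 50000 nM. In this assay compound 2 likewise gives only a limit, > 50000 nM. The step that the two limits leave unreadable from compound 1 to compound 2 therefore cannot be sized, since both values rest on (the limit of > 50000 nM in this assay, at which 2 of the 2 values shown sit). Compound 2 thus stands at the limit of this assay, with no number of its own on which a change could be read.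

Compound 3 `C/C(=C\c1cc(-c2ccc(C#N)cc2)cs1)C(N)=O` differs from compound 2 by cyano in place of fluoro on an aromatic carbon. Among the measured compounds shown here, the only measured step, a step that the two limits leave unreadable from compound 1 to compound 2, exchanged one small group on an aromatic carbon and left the read-out at the limit, so it offers no size to carry forward. With nothing to suggest a readable shift in this assay, compound 3 is expected to remain near the limit, the step that the limit leaves unreadable from compound 2 to compound 3 being an expectation of no change beyond the scatter. The estimate for compound 3 in this assay is 70000 nM, within 20000 nM to 300000 nM, and a limit rather than a number is expected to be the likelier report.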

Compound 3, half-maximal inhibitory concentration: > 50000 nM
Compound 3: a limit, no number; the forecaster's own chance of this, stated with the estimate: 75%; the middle value lies beyond the limit too.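

No step from compound 1 or compound 2 to compound 3 can be read, because compound 3, like the other two, gives only a limit and no number: the limit of > 50000 nM in this assay, at which 3 of the 3 values shown sit.

The compounds shown leave open whether methyl, fluoro and cyano on the aromatic carbon differ at all in this assay.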